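The compounds below may be only part of what the source reports. "The series", "measured", "known", "first", "only" and "open" are said of these compounds alone.

Working notes on the series.

Compound 3 `Cc1ccc(NC(=S)NC(=O)c2ccc(OCc3ccccc3Cl)cc2)cc1-c1nc2ccccc2[nH]1` is one of two compounds with a number in a functional assay on MGC-803 cells (Homo sapiens) for inhibition, read by MTT assay, with a stated time of 48 h; a higher number here means a weaker inhibitor, a lower number a stronger inhibitor: compound 3 gives 45000 nM. Compound 2 `Cc1ccc(COc2ccc(C(=O)NC(=S)Nc3ccc(C)c(-c4nc5ccccc5[nH]4)c3)cc2)cc1` gives 4980 nM, and the step of a 9.0-fold higher number from compound 2 to compound 3 (0.96 log units; beyond the scatter) separates them, so compound 3 sits at the higher of the two numbers. Compound 1 `Cc1ccc(NC(=S)NC(=O)c2ccc(OCc3cccc(Cl)c3Cl)cc2)cc1-c1nc2ccccc2[nH]1` reaches only a limit in this assay, > 100000 nM, and that is the limit described as the limit of > 100000 nM in this assay, at which 1 of the 3 values shown sits.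

Compound 4 `Cc1ccc(NC(=S)NC(=O)c2ccc(OCc3ccc(Cl)c(Cl)c3)cc2)cc1-c1nc2ccccc2[nH]1` is not yet measured. It differs from compound 3 by 3,4-dichlorophenyl in place of 2-chlorophenyl on a saturated chain carbon bound to an oxygen on an aromatic ring. The step that bears most directly on this change is an at least 2.2-fold lower number from compound 1 to compound 3 (0.34 log units; beyond the scatter), in which a chloro was removed from the benzyl ring; the reverse direction, adding a chloro, therefore points to a higher number. Compound 4 keeps two chloros, as in compound 1, though at other positions, so the expected direction is toward a weaker inhibitor and the step is expected to read a 1.8-fold higher number from compound 3 to compound 4 (0.25 log units; within the scatter). Compound 4 is thus estimated at 80000 nM, within a range of 25000 nM to 250000 nM, with a real chance that this assay again reports only a limit.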

Compound 4, half-maximal inhibitory concentration: 6390 nM
Compound 4: middle estimate off by 13-fold (1.10 log units), on the high side; measured number below the stated range.
By their numbers in this assay, from the lowest: compounds 2 and 4 (each within the scatter of the next); then compound 3. At a limit, above all of these: compound 1.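

On the saturated chain carbon bound to an oxygen on an aromatic ring, the count of chloro groups does not by itself order the series in this assay: 3,4-dichlorophenyl carries one chloro more than 2-chlorophenyl, yet the change gives a 7.0-fold lower number from compound 3 to compound 4 (0.85 log units; beyond the scatter), against the direction of an at least 2.2-fold lower number from compound 1 to compound 3 (0.34 log units; beyond the scatter). The two dichlorophenyl groups also differ widely, with an at least 15-fold lower number from compound 1 to compound 4 (1.19 log units; beyond the scatter), and that step rests on a limit, not a number: the limit of > 100000 nM in this assay, at which 1 of the 4 values shown sits. 3,4-Dichlorophenyl and 4-methylphenyl cannot be told apart here, with a 1.3-fold higher number from compound 2 to compound 4 (0.11 log units; within the scatter).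

The compounds shown leave open whether the gain with 3,4-dichlorophenyl would persist with 4-chlorophenyl or 3-chlorophenyl, which would separate the contribution of each chloro. On these data alone, how 4-methoxyphenyl or a longer chain in place of the single saturated carbon would read also remains open.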